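The compounds below may be only part of what the source reports. "The series", "measured", "known", "first", "only" and "open" are said of these compounds alone.

Compound 1, `CN(C)CCNc1nc(N/N=C/c2ccc(Cl)cc2)nc2ccccc12`, gives 370 nM in a functional assay on HepG2 cells (Homo sapiens) for cytotoxicity, read by MTT assay, with a stated time of 72 h; on this read-out higher numbers stand for weaker inhibition and lower numbers for stronger inhibition. Compound 2, `CN(C)CCCNc1nc(N/N=C/c2ccc(Cl)cc2)nc2ccccc12`, carries the change (dimethylamino)methyl in place of dimethylamino on a saturated chain carbon, two bonds along the chain from a nitrogen on an aromatic ring and gives 550 nM in this assay; the step is a 1.5-fold higher number from compound 1 to compound 2 (0.17 log units; within the scatter). Compound 3, `CN(C)CCNc1nc(N/N=C/c2nccn2Cc2ccccc2)nc2ccccc12`, shares the chain of compound 1 but stands on a different core; the difference between the two cores is not broken down here. In this assay compound 3 gives 9600 nM, the highest number of the three measured compounds.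

Compound 4, `CN(C)CCCNc1nc(N/N=C/c2nccn2Cc2ccccc2)nc2ccccc12`, has not been measured. It differs from compound 3 by (dimethylamino)methyl in place of dimethylamino on a saturated chain carbon, two bonds along the chain from a nitrogen on an aromatic ring, which is the same change as that from compound 1 to compound 2, at the same place. Among the compounds with values here, that earlier step lay within the usual scatter, so the account expects a step of about the same size, a 1.3-fold higher number from compound 3 to compound 4 (0.10 log units; within the scatter), because the only measured instance is a 1.5-fold higher number from compound 1 to compound 2 (0.17 log units; within the scatter). Whether the same change behaves alike on the core of compound 3 is not shown by any measured pair. For compound 4 the estimate in this assay is 12000 nM, with a range from 5500 nM to 27000 nM.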

Compound 4, half-maximal inhibitory concentration: 4040 nM
For compound 4 the middle estimate is 3.0-fold (0.47 log units) above the measured one; the measured number lies below the stated range.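

On the second core the change of dimethylamino to (dimethylamino)methyl, on a saturated chain carbon, two bonds along the chain from a nitrogen on an aromatic ring, gives a 2.4-fold lower number from compound 3 to compound 4 (0.38 log units; beyond the scatter) in this assay. Set beside the earlier step, this shows that in this series the size of the change cannot simply be carried from one core to the other, as the two steps differ: the same change on two cores in this assay, a 1.5-fold higher number (0.17 log units; within the scatter) from compound 1 to compound 2 and a 2.4-fold lower number (0.38 log units; beyond the scatter) from compound 3 to compound 4, 3.5-fold (0.55 log units) apart, beyond the scatter of two such steps. The comparison rests on a single pair on each core, so it shows neither why the two cores part nor how the change would behave on any further core.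

The compounds shown leave open how a chain longer than 3-(dimethylamino)propyl would read on either core, and whether the two cores would keep apart along such a series. Also open, on these data alone, is what a diethylamino group or a primary amine at the end of the chain would give in this assay.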